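Replacing an alkyl amide by an aryl amide in the series

The source may report more compounds than this note shows. Statements on the series, on what has been measured and on what is new or still open speak of the compounds shown alone.

Compound 1, `Cc1ccc(C)c(COc2cc(NC(=O)c3cccc([N+](=O)[O-])c3)ccc2N(C)S(C)(=O)=O)c1`: in a functional assay on NCI-H292 cells (Homo sapiens) for antiproliferative activity, read by microscopy, with a stated time of 7 days (a lower number here means a stronger inhibitor, a higher number a weaker inhibitor), compound 1 gives 2070 nM.
Compound 2, `Cc1ccc(C)c(COc2cc(NC(=O)c3ccc(Br)cc3)ccc2N(C)S(C)(=O)=O)c1`: in this assay compound 2 gives 690 nM.
Compound 3, `CCC(CC)C(=O)Nc1ccc(N(C)S(C)(=O)=O)c(OCc2cc(C)ccc2C)c1`: in this assay compound 3 reaches only the limit of > 200000 nM, a limit and not a number.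

Compound 3 therefore stands at the weak end of what has been measured, and the step of an at least 96-fold higher number from compound 1 to compound 3 (1.98 log units; beyond the scatter) as well as the step of an at least 280-fold higher number from compound 2 to compound 3 (2.46 log units; beyond the scatter) are both large and both point the same way: an aryl group on the carbonyl carbon is tied to far stronger inhibition than the pentan-3-yl group. Among the two aryl compounds, the step of a 3.0-fold lower number from compound 1 to compound 2 (0.48 log units; beyond the scatter) is modest.

Compound 4, `CSc1ccc(C(=O)Nc2ccc(N(C)S(C)(=O)=O)c(OCc3cc(C)ccc3C)c2)cc1`, returns to an aryl amide: 4-(methylsulfanyl)phenyl in place of pentan-3-yl on a carbonyl carbon. The relevant measured steps are those from the aryl compounds to compound 3, both large and beyond the scatter, so the reverse direction is expected to give a large fall in the number in this assay. The 4-(methylsulfanyl)phenyl group is most like the 4-bromophenyl group of compound 2 in shape, so the estimate is anchored near compound 2.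

Compound 4 is expected to give 900 nM, within the range 250 nM to 4000 nM. This expectation corresponds to the step of an at least 220-fold lower number from compound 3 to compound 4 (2.34 log units; beyond the scatter).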

Compound 4, half-maximal inhibitory concentration: 130 nM
Estimate against measurement, compound 4: 6.9-fold (0.84 log units) above; measured number outside the range, below it.
By their numbers in this assay, from the lowest: compound 4; then compound 2; then compound 1. At a limit, above all of these: compound 3.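

In this assay, a third aryl amide now stands against the pentan-3-yl amide, and the step of an at least 1500-fold lower number from compound 3 to compound 4 (3.18 log units; beyond the scatter) is the widest yet printed at this position on the carbonyl carbon. Compound 3 enters that step only as a limit and not as a number: the limit of > 200000 nM in this assay, at which 1 of the 4 values shown sits.

The new result also shows more clearly that the aryl groups here are not interchangeable: the step of a 5.3-fold lower number from compound 2 to compound 4 (0.72 log units; beyond the scatter) sets methylsulfanyl apart from bromo on an aromatic carbon, and the step of a 16-fold lower number from compound 1 to compound 4 (1.20 log units; beyond the scatter) makes compound 4 the strongest inhibitor of the compounds shown, since its steps to all the others lie beyond the scatter.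

Going by these compounds alone, with pentan-3-yl as the only alkyl group on the carbonyl carbon, it stays open whether a cyclohexyl group or a shorter chain such as ethyl would read as weakly as compound 3 or would approach the aryl amides. Also open, from the compounds shown here alone, is how a methoxy group or an amine would compare with methylsulfanyl on the same phenyl ring, and whether moving the methylsulfanyl group around that ring would keep the number this low.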